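Nitrofuranoyl ester in place of chlorobenzoyl on the core

The source may hold more compounds than are shown below. What is called first, only, known or untested is meant among the compounds shown, and "the series" means these compounds.

Measured compounds:
- compound 1 `CC1=CC[C@H]2[C@H](CC[C@]2(C)O)C(C)(C)[C@@H]1CC[C@H]1[C@]2(C)CC[C@H](OC(=O)c3ccc(Cl)cc3)C(C)(C)O[C@H]2CC[C@@]1(C)O`: 10300 nM
- compound 2 `CC1=CC[C@H]2[C@H](CC[C@]2(C)O)C(C)(C)[C@@H]1CC[C@H]1[C@]2(C)CC/C(=N/O)C(C)(C)O[C@H]2CC[C@@]1(C)O`: 42700 nM
- compound 3 `CC1=CC[C@H]2[C@H](CC[C@]2(C)O)C(C)(C)[C@@H]1CC[C@H]1[C@]2(C)CC/C(=N/OCc3ccccc3)C(C)(C)O[C@H]2CC[C@@]1(C)O`: 38200 nM

In a functional assay on MDA-MB-231 cells (Homo sapiens) for antiproliferative activity, read by MTT assay, with a stated time of 72 h (on this read-out higher numbers stand for weaker inhibition and lower numbers for stronger inhibition), compound 1 gives 10300 nM, the lowest number of the three. Within the data shown here, compound 2, the oxime, gives 42700 nM, and compound 3, its benzyl ether, gives 38200 nM; the only step measured in one place, a 1.1-fold lower number from compound 2 to compound 3 (0.05 log units; within the scatter), does not move the number beyond the scatter. Among the measured compounds shown here, compound 1 differs from compounds 2 and 3 in more than one place, so no single step connects the ester to the oximes; the values alone show the ester well below both.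

Compound 4 `CC1=CC[C@H]2[C@H](CC[C@]2(C)O)C(C)(C)[C@@H]1CC[C@H]1[C@]2(C)CC[C@H](OC(=O)c3ccc([N+](=O)[O-])o3)C(C)(C)O[C@H]2CC[C@@]1(C)O` keeps the ester of compound 1 and changes only its aryl part: 5-nitrofuran-2-yl in place of 4-chlorophenyl on a carbonyl carbon. For the measured compounds named here, no measured step touches the carbonyl substituent, so nothing here bears directly on this change. Going by the values given here, the one step available, a 1.1-fold lower number from compound 2 to compound 3 (0.05 log units; within the scatter), concerns a different position and shows a change at the periphery leaving this assay unmoved. The working expectation is therefore that compound 4 stays near compound 1, with the step of a 1.3-fold lower number from compound 1 to compound 4 (0.11 log units; within the scatter) expected to fall within or close to the scatter. Compound 4 is estimated at 8000 nM, within a range of 3000 nM to 25000 nM.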

Compound 4, half-maximal inhibitory concentration: 11100 nM
Estimate against measurement, compound 4: 1.4-fold (0.14 log units) below; low and high end bracket the measured number.
By their numbers in this assay, from the lowest: compounds 1 and 4 (each within the scatter of the next); then compounds 3 and 2 (each within the scatter of the next).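

In this assay, among these compounds, the step of a 1.1-fold higher number from compound 1 to compound 4 (0.03 log units; within the scatter) gives the first reading at the carbonyl substituent of the ester, and on this read-out 4-chlorophenyl and 5-nitrofuran-2-yl cannot be told apart. The two groups differ in much of what is counted: a six-membered aromatic ring of carbon only with 0 hydrogen-bond acceptors leaves, and a five-membered aromatic ring with 1 hetero atom and 3 hydrogen-bond acceptors enters. For this one pair, the number therefore does not follow ring size, hetero atom content or acceptor count, although a single pair supports no general rule for the position. No measurement is available to explain why the two numbers stay within the scatter.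

As far as these compounds go, whether this insensitivity extends beyond aromatic rings remains open, and a cyclohexyl group, a longer alkyl chain or a phenyl ring carrying an amine or a carboxylic acid on the carbonyl carbon would test it. From the compounds shown here alone, it also remains open whether the ester link matters, which an amide in its place on the shared core would address.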